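This account rests on a few compounds, and the source may have more. Where it says the series, first, only, none or still open, it means among the compounds named here.

Going by the values given here, compound 1, with the structure `O=S(=O)(Nc1ccc(-c2nc3ccccc3o2)cc1)c1cccc(O)c1`, is the only compound of this set with a number of its own: in an assay on cells for inhibition of HSP60/HSP10 (Homo sapiens), with a stated time of 60 min (on this read-out higher numbers stand for weaker inhibition and lower numbers for stronger inhibition), compound 1 gives 62000 nM. Compound 2, with the structure `COc1ccccc1S(=O)(=O)Nc1ccc(-c2nc3ccccc3o2)cc1`, stands at the limit of this assay, where compound 2 gives > 100000 nM, a limit and not a number. Among the compounds with values here, the single measured step, an at least 1.6-fold higher number from compound 1 to compound 2 (0.20 log units; that floor lies within the scatter), is therefore itself only a floor, and the limit of > 100000 nM in this assay, at which 1 of the 2 values shown sits, marks where compound 2 sits. Compound 3, with the structure `Cc1cccc(S(=O)(=O)Nc2ccc(-c3nc4ccccc4o3)cc2)c1`, differs from compound 2 by 3-methylphenyl in place of 2-methoxyphenyl on a sulfonyl sulfur. Within the data shown here, the one step recorded, an at least 1.6-fold higher number from compound 1 to compound 2 (0.20 log units; that floor lies within the scatter), bears on a change at the same sulfonyl sulfur but involves different groups, so it sets no firm direction for the present step. Compound 3 is expected to remain weak, with a step of about a number no higher from compound 2 to compound 3 (the limit leaves the size open) in this assay, and an estimated value of 100000 nM, within the range from 40000 nM to 300000 nM.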

Compound 3, half-maximal inhibitory concentration: > 100000 nM
Compound 3: a limit, no number (the forecaster's own chance of this, stated with the estimate: 55%); the middle value lies on the limit itself.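

Compound 3 is now a second compound at the limit of this assay, and the step from compound 2 cannot be read, so replacing 2-methoxyphenyl with 3-methylphenyl on the sulfonyl sulfur yields no measurable change in either direction. What compound 3 adds is a comparison with compound 1 at a single place, methyl in place of hydroxy on an aromatic carbon, which gives an at least 1.6-fold higher number from compound 1 to compound 3 (0.20 log units; that floor lies within the scatter). Compound 1 alone keeps a number of its own, and the other two compounds share one ceiling: the limit of > 100000 nM in this assay, at which 2 of the 3 values shown sit.

The compounds shown leave open whether the hydroxy matters at all, and how compound 2 and compound 3 would compare if both could be given numbers. They also leave open whether an amine or a carboxylic acid on that aromatic carbon would give a lower number than compound 1.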